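Chloro added to the chlorophenyl tail: an expectation

The compounds below may be only part of what the source reports. "The series", "measured", "known", "first", "only" and "open" are said of these compounds alone.

Compound 1 `C#CCNC1CCc2c(SCCc3ccc(Cl)cc3)cccc21` was measured in an ADME assay on isolated protein for inhibition of Amine oxidase [flavin-containing] B (Homo sapiens) (a lower number here means a stronger inhibitor, a higher number a weaker inhibitor), and gave 920 nM. Compound 2 `C#CCNC1CCc2c(SCCc3cccc(Cl)c3)cccc21`, which carries its single chloro one position away, was entered in this assay and is recorded there as "not determined" (no result reported), so compound 2 stands on no number of its own. Compound 3 `C#CCNC1CCc2c(SCCc3ccc(Cl)c(Cl)c3)cccc21` differs from compound 2 by chloro in place of hydrogen on an aromatic carbon. For the measured compounds named here, no measured pair records this change, so its size rests on expectation alone: in this assay a modest step is expected, most likely toward stronger inhibition, though a step no larger than the usual scatter would not surprise. The half-maximal inhibitory concentration of compound 3 in this assay is therefore estimated at 500 nM, with the range from 150 nM to 2500 nM taken as the band within which a repeat measurement is expected to fall.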

Compound 3, half-maximal inhibitory concentration: 2820 nM
Beside the measured number, compound 3's estimate is 5.6-fold (0.75 log units) below it; the measured number lies above the stated range.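

In this assay, a second chloro on the chlorophenyl tail weakens inhibition rather than strengthening it, with a 3.1-fold higher number from compound 1 to compound 3 (0.49 log units; beyond the scatter), so this position on the tail of compound 1 does not accept a chloro without loss. The step from compound 2 cannot be read, and the effect of this chloro on the 3-chlorophenyl compound therefore remains unmeasured. Nothing in the available data bears on the reason for this weakening.

As far as these compounds go, it remains open whether the loss is specific to chloro or would also appear with a fluoro or methoxy group at this position. Also open, from the compounds shown here alone, is whether a longer chain to the 3,4-dichlorophenyl ring would keep, recover or deepen this loss.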